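Homologation of the Aryl Substituent in Compound 3

The source may hold more compounds than are shown below. What is called first, only, known or untested is meant among the compounds shown, and "the series" means these compounds.

Compound 3 `COc1ncc(C(F)(F)F)cc1CO[C@H]1[C@H](C(C)(C)C)[C@@H](C(=O)O)N(C(=O)[C@@H]2CCCCO2)[C@H]1c1ccccc1C(C)C` gives 35 nM in an assay on cells with Cystic fibrosis transmembrane conductance regulator variant F508del (Homo sapiens) as the target, read by voltage clamp, with a stated time of 24 h, in the presence of a further agent that is not named here (a lower number here means that less compound is needed, a higher number that more compound is needed for the effect), the lowest of the three numbers measured. Compound 1 `COc1ccc(C(F)(F)F)cc1CO[C@H]1[C@H](C(C)(C)C)[C@@H](C(=O)O)N(C(=O)C2CCCCC2)[C@H]1c1ccccc1` gives 173 nM and compound 2 `COc1ncc(C2CCCC2)cc1CO[C@H]1[C@H](C(C)(C)C)[C@@H](C(=O)O)N(C(=O)C2CCCCC2)[C@H]1c1ccccc1` gives 247 nM in this assay; both stand beyond the scatter above compound 3. Compound 4 `COc1ncc(C(F)(F)F)cc1CO[C@H]1[C@H](C(C)(C)C)[C@@H](C(=O)O)N(C(=O)[C@@H]2CCCCO2)[C@H]1c1ccccc1CC(C)C` differs from compound 3 in one place: isobutyl in place of isopropyl on an aromatic carbon. Among the compounds with values here, no measured pair shows a step of this kind, so its size can only be estimated. Such a one-carbon lengthening is expected to leave the number close to that of compound 3. The step from this change is expected to be a 1.3-fold higher number from compound 3 to compound 4 (0.11 log units; within the scatter), within the scatter. Compound 4 is estimated at 45 nM, with a range from 15 nM to 135 nM.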

Compound 4, half-maximal effective concentration: 52 nM
Estimate against measurement, compound 4: 1.2-fold (0.06 log units) below; the measured number falls inside the stated range.
By their numbers in this assay, from the lowest: compounds 3 and 4 (each within the scatter of the next); then compounds 1 and 2 (each within the scatter of the next).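

Replacing isopropyl with isobutyl on this aromatic carbon, ortho to a large group, gives a 1.5-fold higher number from compound 3 to compound 4 (0.17 log units; within the scatter) in this assay. Within the data shown here, this is the first step that can be read at this position, and it shows that the isobutyl chain is tolerated here, which the earlier compounds, differing in several places, could not show. Nothing measured bears on the reason for this result. Going by these compounds, whether a longer chain, a cyclohexyl group or an amine would be tolerated on this carbon remains open.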